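The source may hold more compounds than are shown below. What is called first, only, known or untested is meant among the compounds shown, and "the series" means these compounds.

Three compounds have been measured in a functional assay on SF-295 cells (Homo sapiens) for cytotoxicity, read by sulforhodamine B assay, with a stated time of 48 h; on this read-out lower numbers stand for higher toxicity in this test and higher numbers for lower toxicity in this test:

- compound 1 `ClCc1ccc(Cn2cnc3c(Cl)ncnc32)cc1`: 24000 nM
- compound 2 `ClCc1ccccc1Cn1cnc2c(Cl)nc(Cl)nc21`: 6020 nM
- compound 3 `ClCc1cccc(Cn2cnc3c(Cl)ncnc32)c1`: 29500 nM

Of the three, compound 2 shows the lowest number in this assay, meaning that it reaches the read-out of this test at the smallest concentration. Its value stands apart from those of compound 1 and compound 3 by more than the usual scatter of this test, while compound 1 and compound 3 themselves lie close enough together that no order between them can be read from their numbers. Compound 2 differs from the other two in that its shared core carries a second chloro group; nothing is recorded about that difference on its own.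

For the measured compounds named here, the next compound, compound 4 `Nc1nc(Cl)c2ncn(Cc3ccccc3CCl)c2n1`, keeps the side chain of compound 2 and alters only one spot on the core: amino in place of chloro on an aromatic carbon. Going by the values given here, no measured pair in this set shows what such a swap does, so any expectation rests on compound 2 alone. A modest loss in potency, that is a somewhat higher number in this assay, seems plausible but is far from certain. Compound 4 is therefore estimated at 12000 nM, within a range of 3000 nM to 40000 nM, which corresponds to an expected step of a 2.0-fold higher number from compound 2 to compound 4 (0.30 log units; within the scatter).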

Compound 4, concentration lethal to 50% of the cells: 63100 nM
Compound 4: middle estimate off by 5.3-fold (0.72 log units), on the low side; measured number outside the range, above it.
By their numbers in this assay, from the lowest: compound 2; then compounds 1 and 3 (each within the scatter of the next); then compound 4.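

Replacing chloro with amino on this aromatic carbon, between two ring nitrogen atoms, is a large change in this assay and not a minor edit: the pair shows a 10-fold higher number from compound 2 to compound 4 (1.02 log units; beyond the scatter) with the side chain held constant. The earlier compounds shown here could not separate the core from the side chain, whereas this pair shows that this one spot on the core can by itself move the number well beyond the scatter. Nothing available explains why the number rises with this swap.

Still open, from the compounds shown here alone, is whether this step is specific to amino, or whether a methoxy or methylamino group on the same carbon would shift the number as far. Also open, going by these compounds, is whether amino at this carbon would have a similar effect with the side chain of compound 1 or compound 3.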